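The source may hold more compounds than are shown below. What is called first, only, known or untested is meant among the compounds shown, and "the series" means these compounds.

Measured compounds:

Compound 1, `Cc1ccc(-c2cc(C)oc(=O)c2)cc1`: in a functional assay on K562 cells (Homo sapiens) for inhibition (a lower number here means a stronger inhibitor, a higher number a weaker inhibitor), compound 1 gives > 50000 nM, which is a limit of the assay.

Compound 2, `Cc1cc(-c2ccc(C=O)cc2)cc(=O)o1`: in this assay compound 2 gives 26000 nM.

Among the compounds with values here, compound 2 thus holds the only measured number in this assay; the other value is a limit, as the limit of > 50000 nM in this assay, at which 1 of the 2 values shown sits, records. The measured step is an at least 1.9-fold lower number from compound 1 to compound 2 (0.28 log units; that floor lies within the scatter).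

Compound 3, `COc1ccc(-c2cc(C)oc(=O)c2)cc1`, differs from compound 2 in one place: methoxy in place of formyl on an aromatic carbon. Within the data shown here, the only measured step bears on this change indirectly, since it exchanged methyl for formyl at the same aromatic carbon, and its floor lies within the scatter. Among the measured compounds shown here, with no measured step for methoxy itself, a change in this assay beyond the scatter is not expected in either direction. Compound 3 is therefore estimated at 35000 nM, within 12000 nM to 100000 nM, which amounts to an expected 1.3-fold higher number from compound 2 to compound 3 (0.13 log units; within the scatter).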

Compound 3, half-maximal inhibitory concentration: > 50000 nM
Compound 3: no number, only a limit; the forecaster's own chance of this, stated with the estimate: 40%; at least 1.4-fold (0.15 log units) between middle value and limit.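

Methoxy in place of formyl on this aromatic carbon gives an at least 1.9-fold higher number from compound 2 to compound 3 (0.28 log units; that floor lies within the scatter), so a group with the same count of heavy atoms does not carry over a measured number in this assay. Compound 3 gives only a limit of the assay, as compound 1 does, which leaves formyl as the only group shown at this position with a number: the limit of > 50000 nM in this assay, at which 2 of the 3 values shown sit. The step from compound 1 to compound 3 cannot be read.

Going by these compounds, what numbers compound 1 and compound 3 would give remains open, and with it any difference between methyl and methoxy at this position. Also open, on these data alone, is whether another group on this carbon, such as a carboxylic acid or an amine, would give a number as formyl does, or one beyond the scatter from that of compound 2.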